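A few compounds are considered here, and "the series" means these few. Any claim that something is new, unique, unknown or untested is made for them only; others in the source may bear on it.

Working notes on the series. Compound 1 `CCCc1nc(CC)c(C(=O)OCc2ccccc2OC)n1Cc1ccc(-c2ccccc2S(=O)(=O)NC(=O)OCCC(C)C)cc1F` gives 1 nM in an assay on isolated protein for binding affinity to Type-2 angiotensin II receptor (Homo sapiens) (a higher number here means a weaker inhibitor, a lower number a stronger inhibitor), the lowest of the three numbers in hand. Compound 2 `CCCc1nc(CC)c(C(=O)OCc2ccccc2S(=O)(=O)c2ccccc2)n1Cc1ccc(-c2ccccc2S(=O)(=O)NC(=O)OCCC(C)C)cc1F` gives 5 nM, and compound 3 `CCCOC(=O)NS(=O)(=O)c1ccccc1-c1ccc(Cn2c(CCC)nc(CC)c2C(=O)OCc2ccccc2-c2ccsc2)c(F)c1` gives 20 nM; compound 3 differs from compound 1 in more than one place, so only its value is noted. Going by the values given here, the step of a 5.0-fold higher number from compound 1 to compound 2 (0.70 log units; beyond the scatter) is the one measured change at the same place in the shared core. Compound 4 `CCCc1nc(CC)c(C(=O)OCCC[S+]([O-])c2ccccc2)n1Cc1ccc(-c2ccccc2S(=O)(=O)NC(=O)OCCC(C)C)cc1F` carries a group of 10 heavy atoms (8 carbon, 1 oxygen, 1 sulfur; one six-membered aromatic ring of carbon only) in place of a group of 8 heavy atoms (7 carbon, 1 oxygen; one six-membered aromatic ring of carbon only), on a saturated chain carbon bound to an oxygen next to a carbonyl group. Among the compounds with values here, the one step that bears on this site already cost potency, and the incoming group is not the one measured, so a modest loss beyond the scatter is expected, a 5.0-fold higher number from compound 1 to compound 4 (0.70 log units; beyond the scatter). Compound 4 is estimated at 5 nM in this assay, within 1 nM to 30 nM.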

Compound 4, half-maximal inhibitory concentration: 1 nM
Beside the measured number, compound 4's estimate is 5.0-fold (0.70 log units) above it, within the range that was stated.
By their numbers in this assay, from the lowest: compounds 1 and 4 (each within the scatter of the next); then compound 2; then compound 3.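

In this assay there is no change at the digits printed from compound 1 to compound 4 (within the scatter) when the 2-methoxyphenyl group on this saturated chain carbon gives way to a group of 10 heavy atoms that includes sulfur. The earlier 5.0-fold higher number from compound 1 to compound 2 (0.70 log units; beyond the scatter) on an aromatic carbon thus does not describe every change in this part of the molecule. No measurement in hand gives a reason for this result.

From the compounds shown here alone, whether a thioether, a sulfone or an all-carbon chain in the entering group would give a similar number stays open. So does the outcome with an amine or a carboxylic acid at the end of the chain.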